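This account rests on a few compounds, and the source may have more. Where it says the series, first, only, none or still open, it means among the compounds named here.

The measured compounds are:
compound 1, `CCc1cc(C(C)=O)c(O)cc1OCCCCCC(C)(C)C#N`, which gives 53% in an assay on isolated protein for binding affinity to leukotriene B4 receptor 1 (Homo sapiens), tested at 1 uM; a lower number here means less inhibition, a higher number more inhibition at the concentration tested (going by the name of the read-out);
compound 2, `CCc1cc(C(C)=O)c(O)cc1OCCCC(C)(C)c1nnn[nH]1`, which gives 76%;
compound 3, `CCc1cc(C(C)=O)c(O)cc1OCCCCCn1cncn1`, which gives 30%.

Compound 3 stands lowest of these three numbers in this assay. Its nearest neighbour is compound 1, the step being a number 23 percentage points lower from compound 1 to compound 3 (beyond the scatter); the furthest is compound 2, with a number 46 percentage points lower from compound 2 to compound 3 (beyond the scatter).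

Compound 4, `CCc1cc(C(C)=O)c(O)cc1OCCCCc1nnn[nH]1`, differs from compound 3 in one place: 1H-tetrazol-5-yl in place of (1H-1,2,4-triazol-1-yl)methyl on a saturated chain carbon, four bonds along the chain from an oxygen on an aromatic ring. Among the compounds with values here, two measured steps bear on this. The step of a number 46 percentage points lower from compound 2 to compound 3 (beyond the scatter) runs the opposite way round a closely related exchange, a tetrazole giving way to a triazole, and the step of a number 23 percentage points higher from compound 1 to compound 2 (beyond the scatter) shows a tetrazole in place of a nitrile going with a higher number. Both point toward a rise when the tetrazole returns. Within the data shown here, compound 2, however, carries two methyl groups that compound 4 lacks, and no measured pair shows what that difference alone does, so the gain is expected to fall short of a full return to the level of compound 2. For compound 4 the expected step is a number 30 percentage points higher from compound 3 to compound 4 (beyond the scatter). The estimate for compound 4 is 60%, with a range from 40% to 80%.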

Compound 4, a percentage reported as inhibition, at one concentration (the size of the read-out at that concentration, not a potency): 19%
Compound 4: the middle estimate sits 41 percentage points above what was measured; measured number below the stated range.
By their numbers in this assay, from the lowest: compound 4; then compound 3; then compound 1; then compound 2.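

Placing a tetrazole on this chain does not by itself bring a high number in this assay: 1H-tetrazol-5-yl in place of (1H-1,2,4-triazol-1-yl)methyl gives a number 11 percentage points lower from compound 3 to compound 4 (beyond the scatter) and not a rise. Compound 2 and compound 4 both carry the tetrazole, and the exchange of 1-(1H-tetrazol-5-yl)-1-methylethyl for (1H-tetrazol-5-yl)methyl, which removes only the methyl groups, gives a number 57 percentage points lower from compound 2 to compound 4 (beyond the scatter) in this same measure, so at this position the methyl groups count for a great deal when the tetrazole is present. The earlier link between a tetrazole and a higher number over a nitrile now rests on compound 2 alone, with compound 4 going against it, as 1H-tetrazol-5-yl in place of 2-cyano-2-methylpropyl gives a number 34 percentage points lower from compound 1 to compound 4 (beyond the scatter) here.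

From the compounds shown here alone, it remains open whether the methyl groups would have the same effect with the triazole or the nitrile, and whether a carboxylic acid or a longer chain could stand in for the tetrazole while they stay in place. No evidence on any measured property of these compounds is available to explain these steps.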